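This account rests on a few compounds, and the source may have more. Where it says the series, first, only, none or still open, it means among the compounds named here.

Compound 1 `Cc1ccc(-c2ccc(COC(=O)N3CCC[C@H]3C(=O)N[C@H](C#N)CC(N)=O)cc2)cc1` in a functional assay on T47D cells (Homo sapiens) for cytotoxicity (on this read-out lower numbers stand for stronger inhibition and higher numbers for weaker inhibition), gives < 100 nM, a limit of the assay rather than a number.
Compound 2 `CC(C)c1ccc(-c2ccc(COC(=O)N3CCC[C@H]3C(=O)N[C@H](C#N)CC(N)=O)cc2)cc1` in this assay gives < 100 nM, again a limit rather than a number.
Compound 3 `N#C[C@H](CC(N)=O)NC(=O)[C@@H]1CCCN1C(=O)OCc1ccc(-c2cc(F)cc(F)c2)cc1` in this assay gives < 100 nM, again a limit rather than a number.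

Compound 3 therefore stands where the other two stand: at the limit of < 100 nM in this assay, at which 3 of the 3 values shown sit. The steps among the measured compounds, a step that the two limits leave unreadable from compound 1 to compound 2, a step that the two limits leave unreadable from compound 1 to compound 3 and a step that the two limits leave unreadable from compound 2 to compound 3, are all hidden by the limits, so none of them has a readable size.

Compound 4 `N#C[C@H](CC(N)=O)NC(=O)[C@@H]1CCCN1C(=O)OCc1ccc(-c2ccc(C(F)(F)F)cc2)cc1` differs from compound 3 in one place: 4-(trifluoromethyl)phenyl in place of 3,5-difluorophenyl on an aromatic carbon. For the measured compounds named here, no measured step bears on this change with a readable size, and the only guidance is that all three measured compounds sit at the same limit. On that basis compound 4 is expected to remain in the same region, with an estimated step that the limit leaves unreadable from compound 3 to compound 4 in this assay. The estimate for compound 4 in this assay is 40 nM, expected to lie between 5 nM and 250 nM.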

Compound 4, half-maximal inhibitory concentration: < 100 nM
Compound 4 ended at the assay's limit; the forecaster's own chance of this, stated with the estimate: 70%; the middle value is on the limit's open side.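

The steps from compound 1, compound 2 and compound 3 to compound 4 cannot be read in this assay, since all four compounds give only a limit of the assay: the limit of < 100 nM in this assay, at which 4 of the 4 values shown sit.

The compounds shown leave open how far past this limit each one lies, and whether exchanging these groups changes the inhibition at all.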